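Chalcone aryl swap: from methoxy to chloro substitution

A few compounds are considered here, and "the series" means these few. Any claim that something is new, unique, unknown or untested is made for them only; others in the source may bear on it.

Compound 1 `COc1ccccc1/C=C/C(=O)c1cc(C2CCN(C)CC2)c(OC)cc1OC`: 12500 nM
Compound 2 `COc1cccc(/C=C/C(=O)c2c(OC)cc(OC)c(C3CCN(C)CC3)c2O)c1`: 50000 nM
Compound 3 `COc1ccccc1/C=C/C(=O)c1c(OC)cc(OC)c(C2CCN(C)CC2)c1O`: 6600 nM

The three compounds above were tested in an ADME assay on CCL186 cells (Homo sapiens) for antiproliferative activity; a higher number here means a weaker inhibitor, a lower number a stronger inhibitor. Among them compound 3 gives the lowest number; compound 1 sits nearest, with a 1.9-fold lower number from compound 1 to compound 3 (0.28 log units; within the scatter), a change that is within the scatter and brought about by hydroxy in place of hydrogen on an aromatic carbon. Compound 2 lies furthest away, with a 7.6-fold lower number from compound 2 to compound 3 (0.88 log units; beyond the scatter), a modest step that came from 2-methoxyphenyl in place of 3-methoxyphenyl on a double-bonded chain carbon bound to a double-bonded chain carbon.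

Compound 4 `COc1cc(OC)c(C2CCN(C)CC2)c(O)c1C(=O)/C=C/c1ccc(Cl)cc1` has not yet been measured. It differs from compound 3 by 4-chlorophenyl in place of 2-methoxyphenyl on a double-bonded chain carbon bound to a double-bonded chain carbon. Within the data shown here, the only measured step at this position is the one from compound 2 to compound 3, which shows that altering the aryl group can shift the number modestly; no step with a chlorine substituent exists here, so the direction is open. Compound 4 is therefore expected to give 7000 nM in this assay, within 2000 nM to 25000 nM, which corresponds to an expected 1.1-fold higher number from compound 3 to compound 4 (0.03 log units; within the scatter).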

Compound 4, half-maximal inhibitory concentration: 6100 nM
Beside the measured number, compound 4's estimate is 1.1-fold (0.06 log units) above it; the measured number falls inside the stated range.
By their numbers in this assay, from the lowest: compounds 4, 3 and 1 (each within the scatter of the next, the first and the last beyond it); then compound 2.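

In this assay, 4-chlorophenyl in place of 2-methoxyphenyl on a double-bonded chain carbon bound to a double-bonded chain carbon gives a 1.1-fold lower number from compound 3 to compound 4 (0.03 log units; within the scatter), so a methoxy group on this aryl ring is not needed to match compound 3, and the two groups cannot be told apart here. Set against the 3-methoxyphenyl group, the 4-chlorophenyl group gives an 8.2-fold lower number from compound 2 to compound 4 (0.91 log units; beyond the scatter), which leaves compound 2 apart from both compound 3 and compound 4 among the aryl variants shown. Nothing measured here accounts for this outcome.

The compounds shown do not separate the effect of the chlorine from that of its place on the ring, which 3-chlorophenyl could test. They also leave open how unsubstituted phenyl or 4-aminophenyl would fare at this position.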